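Swapping methylcarbamoyl for 1H-tetrazol-5-yl at the chain end

A few compounds are considered here, and "the series" means these few. Any claim that something is new, unique, unknown or untested is made for them only; others in the source may bear on it.

In a functional assay for inhibition, with Homo sapiens as the target (on this read-out higher numbers stand for weaker inhibition and lower numbers for stronger inhibition), compound 1 `CC(C)(C)OC(=O)COCCCCCCn1nc(-c2ccccc2)c(-c2ccccc2)c1-c1ccccc1` gives only a limit (> 62000 nM). Compound 2 `CNC(=O)CCCCCCCCn1nc(-c2ccccc2)c(-c2ccccc2)c1-c1ccccc1` also gives only a limit (> 68000 nM), so it has no numerical position in the series, and the other value available is a limit too. Going by the values given here, the one measured step is a step that the two limits leave unreadable from compound 1 to compound 2 and so supplies no size to carry forward.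

Compound 3 `c1ccc(-c2nn(CCCCCCCCc3nnn[nH]3)c(-c3ccccc3)c2-c2ccccc2)cc1` differs from compound 2 by 1H-tetrazol-5-yl in place of methylcarbamoyl on a saturated chain carbon, eight bonds along the chain from an aromatic nitrogen. Among the compounds with values here, neither end group tested so far has produced a number, and the new end group has no measured precedent in this set. Within the data shown here, the only reference point is compound 2 at > 68000 nM, which is a limit, so the direction can be judged only loosely and the size hardly at all. The tentative expectation is an at least 4.5-fold lower number from compound 2 to compound 3 (0.65 log units; beyond the scatter), towards stronger inhibition, and another limit remains quite possible. For compound 3 the estimated half-maximal inhibitory concentration is 15000 nM (expected range 1500 nM to 70000 nM).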

Compound 3, half-maximal inhibitory concentration: 1040 nM
The estimate for compound 3 lay 14-fold (1.16 log units) above the measured number; measured number below the stated range.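

In this assay, replacing methylcarbamoyl with 1H-tetrazol-5-yl on a saturated chain carbon, eight bonds along the chain from an aromatic nitrogen, gives an at least 65-fold lower number from compound 2 to compound 3 (1.81 log units; beyond the scatter), and compound 3 supplies the only true number among the compounds shown. Read at the cut six bonds along the chain from the aromatic nitrogen, 2-(1H-tetrazol-5-yl)ethyl in place of (tert-butoxycarbonyl)methoxy gives an at least 59-fold lower number from compound 1 to compound 3 (1.77 log units; beyond the scatter), so with the shared core unchanged, the group at the chain end is enough to separate a measurable inhibitor from the two compounds that gave no number. The true size of the step from compound 2 remains unknown because its starting point is a limit and not a number: the limit of > 68000 nM in this assay, at which 1 of the 3 values shown sits.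

The step from compound 1 to compound 2 cannot be read, so those two end groups cannot be ranked against each other. The compounds shown leave open whether the drop in the read-out is specific to 1H-tetrazol-5-yl or would also appear with a carboxylic acid at the chain end, and whether a shorter or longer chain carrying 1H-tetrazol-5-yl would retain it.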